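From compound 3 to compound 4: the 2-fluorophenyl step

The compounds below may be only part of what the source reports. "The series", "measured", "known", "first", "only" and "open" are said of these compounds alone.

Measured in a physicochemical assay for solubility; a higher number here means a more soluble compound, a lower number a less soluble compound:
- compound 1 (`CNC(=O)c1cc(C(=O)NC2CC2)cn(Cc2cccc3cn[nH]c23)c1=O`): >= 181 ug/mL, a limit
- compound 2 (`CNC(=O)c1cc(C(=O)NC2CC2)cn(Cc2cccc(OC)c2)c1=O`): 79 ug/mL
- compound 3 (`CNC(=O)c1cc(C(=O)NC2CC2)cn(Cc2ccc3nc[nH]c3c2)c1=O`): >= 163 ug/mL, a limit

Compound 3 stands at a limit, not at a number. The change to compound 4 (`CNC(=O)c1cc(C(=O)NC2CC2)cn(Cc2ccccc2F)c1=O`) is 2-fluorophenyl in place of 1H-benzimidazol-6-yl on a saturated chain carbon bound to an aromatic nitrogen. Like the 2-fluorophenyl, the 3-methoxyphenyl of compound 2 has one six-membered aromatic ring of carbon only, so two steps bear on it. On these data alone, these are an at least 2.2-fold lower number from compound 1 to compound 2 (0.36 log units; beyond the scatter) and an at least 2.0-fold higher number from compound 2 to compound 3 (0.31 log units; beyond the scatter), the second read in reverse; both are beyond the scatter, and their true size stays open. A fall in this assay is therefore expected, an at least 2.0-fold lower number from compound 3 to compound 4 (0.30 log units; that floor lies within the scatter), towards the level of compound 2. For compound 4 the estimate is 80 ug/mL, with an expected range of 35 ug/mL to 180 ug/mL.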

Compound 4, solubility: >= 145 ug/mL
Compound 4 ended at the assay's limit (the forecaster's own chance of this, stated with the estimate: 10%); middle value at least 1.8-fold (0.25 log units) from the limit.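

In this assay compound 4 gives >= 145 ug/mL, which is a limit and not a number. Replacing 3-methoxyphenyl with 2-fluorophenyl gives an at least 1.8-fold higher number from compound 2 to compound 4 (0.26 log units; that floor lies within the scatter), so a ring of carbon only at this place need not stay at the level of compound 2, although this floor alone shows no rise beyond the scatter. The steps from compound 1 and compound 3 to compound 4 cannot be read, which leaves compound 2 as the only one of the four with a number.

On these data alone, the true values of compound 1, compound 3 and compound 4 stay open. Also open, as far as these compounds go, is how an amine or a carboxylic acid on the aromatic ring at this place would read in this assay.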